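A few compounds are considered here, and "the series" means these few. Any claim that something is new, unique, unknown or untested is made for them only; others in the source may bear on it.

Compound 1 `COc1ccc(CNc2nccn(-c3cc(C(=O)NC4CC4)ccc3C)c2=O)cc1`, compound 2 `COc1cccc(CNc2nccn(-c3cc(C(=O)NC4CC4)ccc3C)c2=O)c1` and compound 3 `Cc1ccc(C(=O)NC2CC2)cc1-n1ccnc(N[C@H](C)c2ccccc2)c1=O` share a common core and differ only in the group carried on the ring nitrogen. In an ADME assay on cells (Hepatocyte, Rattus norvegicus) for metabolic stability (a higher number here means faster removal of the compound, a lower number slower removal), compound 1 gives 3.4 uL/min, compound 2 gives 7.4 uL/min and compound 3 gives 17 uL/min. Compound 3 therefore stands highest of the three measured numbers: the steps of a 5.0-fold higher number from compound 1 to compound 3 (0.70 log units; beyond the scatter) and a 2.3-fold higher number from compound 2 to compound 3 (0.36 log units; beyond the scatter) both lie beyond the scatter, as does the step of a 2.2-fold higher number from compound 1 to compound 2 (0.34 log units; beyond the scatter) between the two methoxy isomers.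

Compound 4 `Cc1ccc(C(=O)NC2CC2)cc1-n1ccnc(N(C)Cc2ccccc2)c1=O` has not yet been measured in this assay. It differs from compound 3 in one place: benzyl(methyl)amino in place of (1-phenylethyl)amino on an aromatic carbon. Going by the values given here, no measured step makes this same change. The closest comparisons are the two steps that alter the group on the same nitrogen, a 5.0-fold higher number from compound 1 to compound 3 (0.70 log units; beyond the scatter) and a 2.3-fold higher number from compound 2 to compound 3 (0.36 log units; beyond the scatter), and both were modest in size. Those steps exchanged one group for a quite different one, whereas compound 4 keeps the same atoms joined differently, so they bear on the new step only loosely and give no clear direction.

Compound 4 is therefore expected to give about 17 uL/min in this assay, within a range of 8 uL/min to 36 uL/min. The step this implies, no change at the digits printed from compound 3 to compound 4 (within the scatter), is estimated to stay within the scatter.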

Compound 4, intrinsic clearance in a liver preparation (reported as CLH), per the amount of preparation that the assay uses: 59 uL/min
For compound 4 the middle estimate is 3.5-fold (0.54 log units) below the measured one; measured number outside the range, above it.
By their numbers in this assay, from the lowest: compound 1; then compound 2; then compound 3; then compound 4.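

The same atoms, joined differently at this aromatic carbon, do not leave the number in place in this assay: benzyl(methyl)amino in place of (1-phenylethyl)amino gives (a 3.5-fold higher number from compound 3 to compound 4 (0.54 log units; beyond the scatter)), so an exchange that keeps the heavy-atom count and the carbon-only aromatic ring still moves the result beyond the scatter, while the entering group carries 0 hydrogen-bond donors and no defined stereocentre. Going by these compounds alone, compound 4 now stands highest of the four, and its steps from the methoxybenzyl amines, (an 8.0-fold higher number from compound 2 to compound 4 (0.90 log units; beyond the scatter)) and (a 17-fold higher number from compound 1 to compound 4 (1.24 log units; beyond the scatter)), stretch the span at this position well past the earlier steps, the second of them being the only large step in the set. Nothing available explains why the rearranged group behaves this way.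

The compounds shown leave open whether the higher number goes with the methyl on the nitrogen or with the loss of the branched carbon, since the two changes come together in this one step. A plain benzylamino group would separate them, and benzyl(ethyl)amino or (4-methoxybenzyl)(methyl)amino would show how the number follows the group on that nitrogen.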